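This account rests on a few compounds, and the source may have more. Where it says the series, first, only, none or still open, it means among the compounds named here.

Going by the values given here, in an ADME assay on HepG2 cells (Homo sapiens) for cytotoxicity, read by MTT assay, with a stated time of 72 h (on this read-out higher numbers stand for lower toxicity in this test and lower numbers for higher toxicity in this test), compound 2 `O=[N+]([O-])c1c(CS(=O)(=O)c2ccccc2)nc2c(-c3ccccc3C(F)(F)F)cc(Cl)cn12` gives 22700 nM, the only actual number so far. Compound 1 `O=[N+]([O-])c1c(CS(=O)(=O)c2ccccc2)nc2c(-c3ccccc3)cc(Cl)cn12` gives > 15600 nM, which is a limit of the assay and not a number. Among the compounds with values here, the only measured step is a step that the limit leaves unreadable from compound 1 to compound 2, and the sole further evidence is the limit of > 15600 nM in this assay, at which 1 of the 2 values shown sits. Compound 3 `O=[N+]([O-])c1c(CS(=O)(=O)c2ccccc2)nc2c(-c3cccs3)cc(Cl)cn12` differs from compound 2 by thiophen-2-yl in place of 2-(trifluoromethyl)phenyl on an aromatic carbon, with thiophen-2-yl in place of 2-(trifluoromethyl)phenyl on an aromatic carbon. Within the data shown here, no measured step covers this exchange, so the reading rests on compound 2 at 22700 nM, and no change beyond the scatter is expected in this assay, with no direction favoured. The expected step is a 1.1-fold lower number from compound 2 to compound 3 (0.03 log units; within the scatter). The estimate for compound 3 is 21000 nM, with an expected range from 9000 nM to 45000 nM.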

Compound 3, half-maximal cytotoxic concentration: > 3900 nM
Compound 3 was reported as a limit; the forecaster's own chance of this, stated with the estimate: 45%; the middle value lies beyond the limit too.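

In this assay, the steps from compound 2 to compound 3 and from compound 1 to compound 3 cannot be read, as the result for compound 3 is a limit and not a number. The compounds shown leave open whether exchanging phenyl, 2-(trifluoromethyl)phenyl and thiophen-2-yl at this aromatic carbon changes the read-out at all.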